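Thiophen-3-yl to Pyridin-3-yl in Two Matched Pairs

The compounds below may be only part of what the source reports. "The series", "measured", "known", "first", "only" and "open" are said of these compounds alone.

Measured compounds:
compound 1 `O=C(/C=C/c1cn(-c2ccccc2)nc1-c1ccsc1)c1ccccc1` — 4700 nM
compound 2 `COc1cc(C(=O)/C=C/c2cn(-c3ccccc3)nc2-c2ccsc2)cc(OC)c1OC` — 3600 nM
compound 3 `O=C(/C=C/c1cn(-c2ccccc2)nc1-c1cccnc1)c1ccccc1` — 2300 nM

In a functional assay on Huh-7 cells (Homo sapiens) for inhibition, read by sulforhodamine B assay, with a stated time of 72 h (a lower number here means a stronger inhibitor, a higher number a weaker inhibitor), compound 1 gives 4700 nM, while compound 3 gives 2300 nM. The change between them, (pyridin-3-yl in place of thiophen-3-yl on an aromatic carbon), produced a step of a 2.0-fold lower number from compound 1 to compound 3 (0.31 log units; beyond the scatter). Compound 2 sits near compound 1 in this assay; the difference between the two cores is not broken down here. Compound 4 `COc1cc(C(=O)/C=C/c2cn(-c3ccccc3)nc2-c2cccnc2)cc(OC)c1OC` carries the same change on the core of compound 2: pyridin-3-yl in place of thiophen-3-yl on an aromatic carbon. The two places are described in the same words, so the change is the same one repeated.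

Compound 4 is expected to show a step of a 2.0-fold lower number from compound 2 to compound 4 (0.30 log units; within the scatter) in this assay, a size chosen because the earlier step of a 2.0-fold lower number from compound 1 to compound 3 (0.31 log units; beyond the scatter) was modest. Compound 4 is therefore estimated at 1800 nM, with a likely range from 900 nM to 3600 nM.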

Compound 4, half-maximal inhibitory concentration: 1900 nM
Beside the measured number, compound 4's estimate is 1.1-fold (0.02 log units) below it; the measured number falls inside the stated range.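

In this assay, pyridin-3-yl in place of thiophen-3-yl gives a 1.9-fold lower number from compound 2 to compound 4 (0.28 log units; within the scatter). Set beside the earlier step, the change carries over from one core to the other at much the same size: the same change on two cores in this assay, a 2.0-fold lower number (0.31 log units; beyond the scatter) from compound 1 to compound 3 and a 1.9-fold lower number (0.28 log units; within the scatter) from compound 2 to compound 4, 1.1-fold (0.03 log units) apart, within the scatter of two such steps. This agreement rests on two cores only, and the newer step alone lies within the scatter, so it shows neither that the change would carry to other cores nor why the number moves.

The compounds shown leave open how a group such as an amine or a carboxylic acid would read at the same place in this assay. They also leave open whether the agreement would hold with a longer chain on the core.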